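Taking the butyl chain off the shared core

A few compounds are considered here, and "the series" means these few. Any claim that something is new, unique, unknown or untested is made for them only; others in the source may bear on it.

Values in a functional assay on HEL cells (Homo sapiens); on this read-out higher numbers stand for lower toxicity in this test and lower numbers for higher toxicity in this test

Compound 1 `CCCCCCCc1cc2cn(COCCO)c(O)nc-2n1` gives 119000 nM
Compound 2 `CCCCc1cc2cn(COCCO)c(O)nc-2n1` gives > 200000 nM as a limit

Compound 2 stands at > 200000 nM and this is a limit of the assay, not a number. Compound 3 `OCCOCn1cc2ccnc-2nc1O` puts hydrogen in place of butyl on an aromatic carbon and leaves the rest of compound 2 unchanged. Among the measured compounds shown here, the only measured step that bears on this is the shortening of the chain, which gave an at least 1.6-fold higher number from compound 1 to compound 2 (0.22 log units; that floor lies within the scatter) and has a floor within the scatter. It involves a saturated chain carbon rather than an aromatic carbon, so it is only a loose guide. No step beyond the scatter is therefore expected in this assay and another reading at the limit is the likeliest result. The estimate amounts to a number no higher from compound 2 to compound 3 (the limit leaves the size open) as the expected change. Compound 3 is estimated at 200000 nM with 110000 nM to 350000 nM as the expected range.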

Compound 3, half-maximal cytotoxic concentration: > 200000 nM
Compound 3: a limit, no number (the forecaster's own chance of this, stated with the estimate: 80%); the middle value lies on the limit itself.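

In this assay compound 3, which carries hydrogen in place of butyl on the aromatic carbon, gives > 200000 nM as a limit of the assay and not a number. Taking off the whole heptyl chain gives an at least 1.6-fold higher number from compound 1 to compound 3 (0.22 log units; that floor lies within the scatter) and so still shows no change that clearly exceeds the usual scatter, even with no chain left at this position. The step from butyl to hydrogen cannot be read, because both compounds sit at the same ceiling: the limit of > 200000 nM in this assay, at which 2 of the 3 values shown sit.

Only compound 1 gives an actual number, so how toxicity in this test depends on chain length remains unsettled. Also open, as far as these compounds go, is whether a chain longer than heptyl, an amine or a carboxylic acid on this aromatic carbon would give a reading below the limit.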